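Notes on a bile acid receptor efficacy series

This account rests on a few compounds, and the source may have more. Where it says the series, first, only, none or still open, it means among the compounds named here.

Compound 1 `Cc1ccccc1-n1nc(C)c2c1NC(=O)[C@H](C)S[C@@H]2c1ccc(-c2ccoc2)cc1`: 40%
Compound 2 `Cc1nn(-c2ccccc2C(F)(F)F)c2c1C(c1ccc(Oc3ccccc3)cc1)SC(C)C(=O)N2`: 50%

In an assay on isolated protein for agonist activity at Bile acid receptor (Homo sapiens), read by AlphaScreen, with a stated time of 30 min (a higher number here means a larger maximal response, a lower number a smaller maximal response), compound 1 gives 40% and compound 2 gives 50%; the two numbers lie within the scatter of each other, so no difference can be read between them. Compound 3 `COc1ccccc1-c1ccc([C@H]2S[C@@H](C)C(=O)Nc3c2c(C)nn3-c2ccccc2C)cc1` differs from compound 1 by 2-methoxyphenyl in place of furan-3-yl on an aromatic carbon. Going by the values given here, no pair of measured compounds separated by a single change is available, so the effect of this change is unknown. The step of a number 5 percentage points higher from compound 1 to compound 3 (within the scatter) is expected to stay within the scatter. Compound 3 is estimated at 45%, range 25% to 70%, in this assay.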

Compound 3, largest response reached (reported as efficacy), in percent of the reference or control that the assay uses: 50%
Compound 3: middle estimate off by 5 percentage points, on the low side, within the range that was stated.
By their numbers in this assay, from the lowest: compounds 1, 2 and 3 (each within the scatter of the next).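

In this assay, 2-methoxyphenyl in place of furan-3-yl, on an aromatic carbon para to a large group, gives a number 10 percentage points higher from compound 1 to compound 3 (within the scatter) and so leaves no readable difference in maximal response. At this position, a six-membered aromatic ring of carbon only and a five-membered aromatic ring with 1 hetero atom cannot be told apart in this read-out. Nothing available bears on the reason for this result.

Still open, from the compounds shown here alone, is whether an amine or a carboxylic acid at this position would move the maximal response beyond the scatter.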